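A few compounds are considered here, and "the series" means these few. Any claim that something is new, unique, unknown or untested is made for them only; others in the source may bear on it.

Three related compounds have been tested in a functional assay on PC-3 cells (Homo sapiens) for inhibition, read by MTT assay, with a stated time of 48 h, tested at 10 uM; on this read-out higher numbers stand for more inhibition of growth at the one concentration tested and lower numbers for less inhibition of growth. In this test compound 1 (`Cc1cc(=O)c2c(O)cc(OCc3ccccc3)c([C@H]3CCN(C)C[C@H]3O)c2o1`) gives 41%, and compound 2 (`Cc1cc(=O)c2c(O)c(CN3CCC(N4CCCCC4)CC3)c(O)c([C@H]3CCN(C)C[C@H]3O)c2o1`) gives 17%. Compound 3 (`Cc1cc(=O)c2c(O)c(CN3CCN(C(=O)OC(C)(C)C)CC3)c(O)c([C@H]3CCN(C)C[C@H]3O)c2o1`) gives 1%, the lowest of the three numbers, and its gaps to both of the others lie beyond the scatter.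

Compound 4 (`CCOC(=O)N1CCN(Cc2c(O)c([C@H]3CCN(C)C[C@H]3O)c3oc(C)cc(=O)c3c2O)CC1`) has not yet been measured. It differs from compound 3 in one place, on an oxygen next to a carbonyl group: ethyl in place of tert-butyl on an oxygen next to a carbonyl group. In words, ethyl stands in place of tert-butyl, which turns tert-butoxycarbonyl into ethoxycarbonyl. For the measured compounds named here, no two measured compounds differ in only one place, so the data give no direct guide to the size of this step in this assay. The expectation therefore stays close to compound 3 at 1%, with compound 2 at 17% as a rough guide to how far the number might rise. The expected change is small and upward: an estimated a number 5 percentage points higher from compound 3 to compound 4 (within the scatter), not beyond the scatter. Compound 4 is expected to give 6%, with an estimated range from 0% to 20%.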

Compound 4, percent growth inhibition at one concentration: 1%
Beside the measured number, compound 4's estimate is 5 percentage points above it; the measured number falls inside the stated range.
By their numbers in this assay, from the lowest: compounds 3 and 4 (each within the scatter of the next); then compound 2; then compound 1.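

In this assay, for the compounds shown here, the swap of tert-butyl for ethyl on an oxygen next to a carbonyl group gives no change at the digits printed from compound 3 to compound 4 (within the scatter), and this is the first single-place comparison. Compound 3 already stands at 1% and no rise appears, so turning tert-butoxycarbonyl into ethoxycarbonyl does not lift the number in this pair, and the smaller ethyl group brings no gain over tert-butyl. Nothing in the data shown explains why the number stays where it is.

The compounds shown leave open whether any other group on this oxygen would move the number, such as methyl, a longer chain like n-butyl, or benzyl, and whether a free amine in place of the whole ethoxycarbonyl group would do so. Going by these compounds alone, compound 1 and compound 2 are each joined to compound 3 and compound 4 by no single-place step, so what separates their higher numbers from this pair cannot be read from these compounds.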